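This account rests on a few compounds, and the source may have more. Where it says the series, first, only, none or still open, it means among the compounds named here.

In a physicochemical assay for lipophilicity, read by HPLC, measured as chromatographic lipophilicity, at pH 7.4 (a lower number here means a more polar compound, a higher number a more lipophilic compound), compound 1 `CCC(=O)N1CCC(C(=O)N2N=CCC2c2ccccc2)CC1` gives 3.2, while compound 2 `O=C(C1CCN(C(=O)C(F)(F)F)CC1)N1N=CCC1c1ccccc1` gives 4.9, the higher of the two numbers. Compound 3 `O=C(c1cn[nH]c1)N1CCC(C(=O)N2N=CCC2c2ccccc2)CC1` differs from compound 2 in one group: 1H-pyrazol-4-yl in place of trifluoromethyl on a carbonyl carbon. Among the measured compounds shown here, the only measured step at this place, with trifluoromethyl replacing ethyl on a carbonyl carbon, is large: a number 1.70 log units higher from compound 1 to compound 2 (beyond the scatter). For the measured compounds named here, no measured compound carries 1H-pyrazol-4-yl, so the range stays wide. Trifluoromethyl leaves here, so a similarly large fall is expected, and the estimated step is a number 1.90 log units lower from compound 2 to compound 3 (beyond the scatter). Compound 3 is expected at 3, with an estimated range of 2.5 to 3.6.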

Compound 3, distribution coefficient: 2.1
Estimate against measurement, compound 3: 0.90 log units above; measured number outside the range, below it.
By their numbers in this assay, from the lowest: compound 3; then compound 1; then compound 2.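

In this assay the change to 1H-pyrazol-4-yl from trifluoromethyl gives a number 2.80 log units lower from compound 2 to compound 3 (beyond the scatter) and the change from ethyl gives a number 1.10 log units lower from compound 1 to compound 3 (beyond the scatter). On this carbonyl carbon, then, the ring does not simply return the number to the ethyl level but takes it lowest of the three groups. Nothing available explains the size of this fall.

Still open, on these data alone, is how a phenyl ring or a 1-methyl-1H-pyrazol-4-yl group would read on this carbonyl carbon. So the compounds shown cannot separate the aromatic ring itself from its hydrogen-bond donor.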